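Methyl for chloro on the benzyl ring of compound 3

The compounds below may be only part of what the source reports. "The series", "measured", "known", "first", "only" and "open" are said of these compounds alone.

In a functional assay on cells for positive allosteric modulation of G-protein coupled receptor 68 (Homo sapiens), read by a luciferase reporter and cAMP accumulation, with a stated time of 30 min, at pH 6.8 and pH 8.3, in the presence of a further agent that is not named here (a higher number here means a more potent compound, by a factor of ten per unit of this negative logarithm, a lower number a less potent compound), compound 3 `Nc1nc(NCc2cccc(Cl)c2)nc(-c2ccccc2CO)n1` gives 4.97, the second highest of the three numbers: compound 2 `Nc1nc(NCc2ccccc2Cl)nc(-c2ccccc2CO)n1` gives 5.07, and compound 1 `Nc1nc(NCc2ccccc2)nc(-c2ccccc2CO)n1` gives 4.35. Compound 4 `Cc1cccc(CNc2nc(N)nc(-c3ccccc3CO)n2)c1` differs from compound 3 by methyl in place of chloro on an aromatic carbon. The step that bears on this site is a number 0.62 log units higher from compound 1 to compound 3 (beyond the scatter), and the comparison a number 0.10 log units lower from compound 2 to compound 3 (within the scatter) shows that where the chloro sits matters little. Going by the values given here, no measured pair shows methyl against chloro, so the size of this step is uncertain; a small change in this assay, in either direction, is expected. Compound 4 is therefore estimated at 4.8, within 4.3 to 5.3, a step of a number 0.17 log units lower from compound 3 to compound 4 (within the scatter).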

Compound 4, negative logarithm of the antagonist equilibrium constant: 4.4
For compound 4 the middle estimate is 0.40 log units above the measured one; the range from low to high includes it.
By their numbers in this assay, from the lowest: compounds 1 and 4 (each within the scatter of the next); then compounds 3 and 2 (each within the scatter of the next).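

Methyl does not reproduce the gain that chloro gives on this benzyl ring: the change shows a number 0.57 log units lower from compound 3 to compound 4 (beyond the scatter), while methyl in place of hydrogen shows a number 0.05 log units higher from compound 1 to compound 4 (within the scatter). The step against the other chloro compound agrees, with a number 0.67 log units lower from compound 2 to compound 4 (beyond the scatter), so among these compounds the rise is confined to the two chloro compounds, and methyl goes against any rise from simply substituting this ring. Nothing measured here accounts for the difference between chloro and methyl. From the compounds shown here alone, whether bromo, fluoro or methoxy at this place would behave like chloro or like methyl stays open.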